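Sulfonamide series: methoxy for methyl at the aryl sulfonyl

The compounds below may be only part of what the source reports. "The series", "measured", "known", "first", "only" and "open" are said of these compounds alone.

Of the compounds shown here, three have numbers so far in an assay on isolated protein for inhibition of cytohesin-2 (Homo sapiens), read by fluorescence, tested at 1 mM; on this read-out lower numbers stand for less inhibition and higher numbers for more inhibition at the one concentration tested (going by the name of the read-out). Compound 1 `O=S(=O)(Nc1ccccc1O)c1ccccc1` gives 21.6% in this assay. Compound 2 `Cc1cc(O)cc(C)c1NS(=O)(=O)c1ccc([N+](=O)[O-])cc1` gives 58.4%. Compound 3 `Cc1ccc(S(=O)(=O)Nc2c(C)cc(O)cc2C)cc1` gives 32.7%, which is the second highest of the three numbers: compound 1 stands nearest, lower by an amount beyond the scatter, and compound 2 stands furthest, higher by an amount beyond the scatter. For the measured compounds named here, the one single-point step recorded, a number 25.7 percentage points lower from compound 2 to compound 3 (beyond the scatter), shows that exchanging the group on the sulfonyl-bearing ring shifts this read-out by a modest amount.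

Compound 4 `COc1ccc(S(=O)(=O)Nc2c(C)cc(O)cc2C)cc1` has not been measured. It differs from compound 3 in one place: methoxy in place of methyl on an aromatic carbon. Going by the values given here, the only measured step that bears on this position is the nitro-to-methyl step from compound 2 to compound 3; no methoxy analogue has a number, so the direction of a methyl-to-methoxy exchange is not anchored by any recorded pair. Given that one step was modest, the expected step is a number 2.3 percentage points higher from compound 3 to compound 4 (within the scatter), with a change in either direction or none beyond the scatter being plausible. The estimate for compound 4 in this assay is 35%, expected to lie between 18% and 52%.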

Compound 4, a percentage reported as inhibition, at one concentration (the size of the read-out at that concentration, not a potency): 32.1%
Compound 4: middle estimate off by 2.9 percentage points, on the high side, within the range that was stated.
By their numbers in this assay, from the lowest: compound 1; then compounds 4 and 3 (each within the scatter of the next); then compound 2.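

In this assay, the methyl-to-methoxy exchange on the aromatic carbon para to a large group gives a number 0.6 percentage points lower from compound 3 to compound 4 (within the scatter), so this read-out does not separate the two groups, even though methoxy brings one hydrogen-bond acceptor that methyl lacks. For the compounds shown here, the nitro-to-methoxy exchange at the same place gives a number 26.3 percentage points lower from compound 2 to compound 4 (beyond the scatter), which means compound 2 now stands apart from two compounds with different groups at this position, where earlier only the single comparison with compound 3 showed this. No supporting measurement is available for reading these steps further.

The open question is whether nitro is alone in standing apart at this position; a nitrile, a trifluoromethyl or a carboxylic acid on the same aromatic carbon would show whether the higher number extends beyond nitro. An amine or a plain hydrogen there would also help place the methyl and methoxy compounds, and compound 1 cannot serve as that reference, as it differs from compound 3 in more than one place.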